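From 3-chlorobenzyl to 2-fluorobenzyl: one small swap

This account rests on a few compounds, and the source may have more. Where it says the series, first, only, none or still open, it means among the compounds named here.

Compound 1 `COc1ccc(/C=C2\CN(C(=S)SCc3cn(Cc4ccccc4F)nn3)C/C(=C\c3ccc(OC)cc3)C2=O)cc1`: "not determined" (no result reported)
Compound 2 `COc1ccc(/C=C2\CN(Cc3cn(Cc4cccc(Cl)c4)nn3)C/C(=C\c3ccc(OC)cc3)C2=O)cc1`: > 100000 nM
Compound 3 `O=C1/C(=C/c2ccccc2F)CN(Cc2cn(Cc3ccc(F)cc3)nn2)C/C1=C\c1ccccc1F`: 46000 nM

These results come from an ADME assay on HEK293 cells (Homo sapiens) for cytotoxicity, read by MTT assay, with a stated time of 24 h; on this read-out higher numbers stand for weaker inhibition and lower numbers for stronger inhibition. In this assay compound 2 gives > 100000 nM, which is a limit of the assay and not a number. The set therefore contains (the limit of > 100000 nM in this assay, at which 1 of the 3 values shown sits). Compound 1 has no result, and compound 3 alone has a true number, 46000 nM.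

Compound 4 `COc1ccc(/C=C2\CN(Cc3cn(Cc4ccccc4F)nn3)C/C(=C\c3ccc(OC)cc3)C2=O)cc1` has not yet been measured. It differs from compound 2 in one place: 2-fluorophenyl in place of 3-chlorophenyl on a saturated chain carbon bound to an aromatic nitrogen. In words, this puts 2-fluorophenyl in place of 3-chlorophenyl on a saturated chain carbon bound to an aromatic nitrogen, so the change can also be read as 3-chlorobenzyl to 2-fluorobenzyl.

For the measured compounds named here, no pair of measured compounds shows what such a swap does, so any forecast is uncertain. The expectation starts from a limit, that of compound 2 at > 100000 nM. Compound 3, which differs more widely, still needs a high concentration, 46000 nM. The expected change an at least 1.1-fold lower number from compound 2 to compound 4 (0.04 log units; that floor lies within the scatter) is small, at most slightly towards stronger inhibition, and the assay may again report only a limit. For compound 4 the estimated value is 90000 nM, with an expected range from 40000 nM to 200000 nM.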

Compound 4, half-maximal inhibitory concentration: > 100000 nM
Compound 4: a limit, no number (the forecaster's own chance of this, stated with the estimate: 50%); middle value at least 1.1-fold (0.04 log units) from the limit.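

In this assay compound 4 gives > 100000 nM, which is a limit of the assay and not a number. No step can be read from compound 2 to compound 4 because both stand at a limit: the limit of > 100000 nM in this assay, at which 2 of the 4 values shown sit.

The compounds shown leave open whether the swap from 3-chlorobenzyl to 2-fluorobenzyl changes cytotoxicity at all.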